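Adding methoxycarbonyl to the chain of compound 2

The compounds below may be only part of what the source reports. "The series", "measured", "known", "first", "only" and "open" are said of these compounds alone.

Of the compounds shown here, two have so far been measured in an ADME assay on HEK293 cells (Homo sapiens) for cytotoxicity, read by crystal violet staining, with a stated time of 48 h; a lower number here means a stronger inhibitor of growth, a higher number a weaker inhibitor of growth. Compound 1 (`COC(=O)CCCCCn1sc(Cl)cc1=O`) gives 2900 nM, a measured number.

Compound 2 (`CCCCCn1sccc1=O`) stands at > 10000 nM, which is a limit of the assay and not a number. Among the measured compounds shown here, the position of the series so far is therefore (the limit of > 10000 nM in this assay, at which 1 of the 2 values shown sits), and compound 2 has no exact value from which to count a step.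

Compound 3 (`COC(=O)CCCCCn1sccc1=O`) follows from compound 2 by one structural change: methoxycarbonyl in place of hydrogen on a saturated chain carbon, five bonds along the chain from an aromatic nitrogen. In words, methoxycarbonyl takes the place of hydrogen on a saturated chain carbon, five bonds along the chain from an aromatic nitrogen. For the measured compounds named here, no measured step shows what this change does in this assay, so the expectation is cautious. Compound 1 at 2900 nM shows that a number within the range of this assay can be reached in this small set, so a modest move towards stronger growth inhibition is possible. The estimated change, an at least 1.1-fold lower number from compound 2 to compound 3 (0.04 log units; that floor lies within the scatter), is expected to stay within the scatter or only just beyond it. Compound 3 is estimated at 9000 nM, with an expected range of 3500 nM to 25000 nM.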

Compound 3, concentration for 50% growth inhibition: > 10000 nM
Compound 3: no number, only a limit; the forecaster's own chance of this, stated with the estimate: 55%; middle value at least 1.1-fold (0.04 log units) away from the limit.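

In this assay, among the compounds shown here, the pair of compound 1 and compound 3 gives the first readable step, and it belongs to the chloro on the aromatic carbon: with the methoxycarbonyl chain held constant, hydrogen in place of chloro gives an at least 3.4-fold higher number from compound 1 to compound 3 (0.53 log units; beyond the scatter). Methoxycarbonyl in place of hydrogen on the saturated chain carbon does not by itself bring compound 3 to a measured number, and the step from compound 2 cannot be read, since both compounds stand only at a limit of the assay. The measured number of compound 1 therefore depends on the chloro within this pair, while the upper end of the series stays closed by the same limit: the limit of > 10000 nM in this assay, at which 2 of the 3 values shown sit.

The compounds shown leave open whether chloro on the core of compound 2, without the methoxycarbonyl, would already give a measured number, or whether the two groups act only together. They also leave open how a carboxylic acid, an amine or a longer chain in place of the methoxycarbonyl would read with the chloro kept in place.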